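A few compounds are considered here, and "the series" means these few. Any claim that something is new, unique, unknown or untested is made for them only; others in the source may bear on it.

Compound 1 `CC/C=C/C(=O)Nc1cccc(Oc2nc(Nc3cccc(OC)c3)nc3ccsc23)c1` in a functional assay on A549 cells (Homo sapiens) for inhibition, read by MTT assay, with a stated time of 72 h (a lower number here means a stronger inhibitor, a higher number a weaker inhibitor), gives 19600 nM.
Compound 2 `COc1ccc(Nc2nc(Oc3cccc(NC(=O)C=C(C)C)c3)c3sccc3n2)cn1` gives 40100 nM.
Compound 3 `COc1ccc(Nc2nc(Oc3cccc(NC(=O)/C=C/C(C)C)c3)c3sccc3n2)cn1` reaches only a limit of the assay, > 50000 nM.

Of the two numbers, compound 2 holds the higher and compound 1 the lower. Within the data shown here, the only measured step from compound 2 is an at least 1.2-fold higher number from compound 2 to compound 3 (0.09 log units; that floor lies within the scatter), which alters the group on the carbonyl carbon and leaves the aryl amine untouched, so no measured step bears on the change to compound 4 `CC(C)=CC(=O)Nc1cccc(Oc2nc(Nc3cccc(C#N)c3)nc3ccsc23)c1`, where (3-cyanophenyl in place of 6-methoxypyridin-3-yl on a nitrogen on an aromatic ring). With nothing measured to point either way, the change is expected to stay within the scatter. Compound 4 is therefore estimated at 32000 nM in this assay, with a range of 12000 nM to 80000 nM. The expected step is a 1.3-fold lower number from compound 2 to compound 4 (0.10 log units; within the scatter).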

Compound 4, half-maximal inhibitory concentration: 16900 nM
For compound 4 the middle estimate is 1.9-fold (0.28 log units) above the measured one; low and high end bracket the measured number.
By their numbers in this assay, from the lowest: compounds 4 and 1 (each within the scatter of the next); then compound 2. At a limit, above all of these: compound 3.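

In this assay, the group on the nitrogen on an aromatic ring is the first place shown to move the number beyond the scatter: 3-cyanophenyl in place of 6-methoxypyridin-3-yl gives a 2.4-fold lower number from compound 2 to compound 4 (0.38 log units; beyond the scatter). The gain is modest, and the numbers stay in a high range, with the assay's limit not far above them: the limit of > 50000 nM in this assay, at which 1 of the 4 values shown sits.

Going by these compounds, whether the step comes from the nitrile or from the loss of the methoxy pyridine remains open. On these data alone, how an unsubstituted phenyl or a phenyl bearing a carboxylic acid would read on this nitrogen also remains open.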